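Swapping the methylpiperazine tail of compound 2 for piperidine

A few compounds are considered here, and "the series" means these few. Any claim that something is new, unique, unknown or untested is made for them only; others in the source may bear on it.

Measured compounds:
Compound 1 `COc1cc2nccc(Oc3ccc(NC(=O)c4ncc(-c5ccc(F)cc5)o4)cc3)c2cc1OC` gives 5590 nM in a functional assay on A549 cells (Homo sapiens) for antiproliferative activity, read by MTT assay, with a stated time of 72 h; on this read-out higher numbers stand for weaker inhibition and lower numbers for stronger inhibition.
Compound 2 `COc1cc2c(Oc3ccc(NC(=O)C4(c5nnc(-c6ccc(F)cc6)o5)CC4)cc3F)ccnc2cc1OCCCN1CCN(C)CC1` gives 143 nM in this assay.
Compound 3 `COc1cc2nccc(Oc3ccc(NC(=O)c4nnc(-c5ccc(F)cc5)o4)cc3)c2cc1OC` gives 5140 nM in this assay.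

Among these three numbers compound 2 stands lowest; compound 3 is nearest to it and compound 1 furthest, and both gaps lie beyond the scatter. For the measured compounds named here, the only step measured between two compounds that differ in one place, a 1.1-fold lower number from compound 1 to compound 3 (0.04 log units; within the scatter), sits within the scatter and concerns the group on the carbonyl carbon, not the tail.

Compound 4 `COc1cc2c(Oc3ccc(NC(=O)C4(c5nnc(-c6ccc(F)cc6)o5)CC4)cc3F)ccnc2cc1OCCCN1CCCCC1` differs from compound 2 in one place: piperidin-1-yl in place of 4-methylpiperazin-1-yl on a saturated chain carbon, three bonds along the chain from an oxygen on an aromatic ring. Going by the values given here, no measured step touches this tail, so there is nothing to lean on beyond the structural change itself, and compound 2 remains the only reference point. Compound 4 is therefore expected to show no step beyond the scatter, a 1.0-fold higher number from compound 2 to compound 4 (0.02 log units; within the scatter). The estimate for compound 4 in this assay is 150 nM, with a range from 60 nM to 400 nM.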

Compound 4, half-maximal inhibitory concentration: 53 nM
For compound 4 the middle estimate is 2.8-fold (0.45 log units) above the measured one; the whole stated range lies above it.
By their numbers in this assay, from the lowest: compound 4; then compound 2; then compounds 3 and 1 (each within the scatter of the next).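

In this assay, the place on a saturated chain carbon, three bonds along the chain from an oxygen on an aromatic ring, responds to the group it carries: piperidin-1-yl in place of 4-methylpiperazin-1-yl gives a 2.7-fold lower number from compound 2 to compound 4 (0.43 log units; beyond the scatter). This is the first one-place step shown that lies beyond the scatter, whereas the earlier 1.1-fold lower number from compound 1 to compound 3 (0.04 log units; within the scatter) concerned the group on the carbonyl carbon and stayed within it. In this pair, the 4-methylpiperazin-1-yl group's second ring nitrogen and its methyl are not needed for the lower number, though no data shown here explain the step.

On these data alone, it remains open whether morpholin-4-yl, pyrrolidin-1-yl or a dimethylamino group would go lower still on the same 3-carbon chain. Also open, as far as these compounds go, is whether the shorter 2-(piperidin-1-yl)ethyl chain would keep the number of compound 4.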